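Replacing the 3,4,5-trihydroxyphenyl group of compound 1

The source may report more compounds than this note shows. Statements on the series, on what has been measured and on what is new or still open speak of the compounds shown alone.

In a physicochemical assay, read by spectrophotometry, with a stated time of 6 min (a lower number here means a stronger inhibitor, a higher number a weaker inhibitor), compound 1 `O=C(CCCc1nc2ccccc2c(=O)[nH]1)N/N=C/c1cc(O)c(O)c(O)c1` gives 40000000 nM, the lowest of the three numbers available. Compound 3 `COc1cc(/C=N/NC(=O)CCCc2nc3ccccc3c(=O)[nH]2)cc(OC)c1O` gives 135000000 nM and compound 2 `O=C(CCc1nc2ccccc2c(=O)[nH]1)N/N=C/c1ccc(Cl)cc1` gives 185000000 nM, both higher than compound 1 beyond the scatter. Compound 4 `COc1ccc(/C=N/NC(=O)CCCc2nc3ccccc3c(=O)[nH]2)cc1` carries 4-methoxyphenyl in place of 3,4,5-trihydroxyphenyl on a carbon with a double bond to nitrogen. For the measured compounds named here, no measured pair isolates this change, so the expectation rests on indirect comparison. Compound 3, which also lacks the 3,4,5-trihydroxyphenyl group, stands at 135000000 nM, and this guides the direction. The expected change in this assay is a weakening beyond the scatter, estimated as a 3.5-fold higher number from compound 1 to compound 4 (0.54 log units; beyond the scatter). For compound 4 the estimate is 140000000 nM, with an expected range of 65000000 nM to 300000000 nM.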

Compound 4, half-maximal inhibitory concentration: 180000000 nM
Compound 4: the middle estimate sits 1.3-fold (0.11 log units) below what was measured; low and high end bracket the measured number.
By their numbers in this assay, from the lowest: compound 1; then compounds 3, 4 and 2 (each within the scatter of the next).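

In this assay, for the compounds shown here, the step of a 4.5-fold higher number from compound 1 to compound 4 (0.65 log units; beyond the scatter) is the first reading of a change at one place, and it shows that the group on the carbon with a double bond to nitrogen affects the number. The change removes hydrogen-bond donors and introduces a methoxy group together, so this step cannot separate the two. Nothing measured here explains the step. Open, from the compounds shown here alone, is how 4-hydroxyphenyl or 3,4-dihydroxyphenyl would read at this place. Either group would help show whether the free hydroxy groups or the methoxy group matter more.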